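The compounds below may be only part of what the source reports. "The series", "measured", "known", "first", "only" and "open" are said of these compounds alone.

Of the compounds shown here, two have been tested in a functional assay on the whole organism (artery, strain albino) with Rattus norvegicus as the target, with a stated time of 15 min, at a dose of 10 mg/kg by the oral route; on this read-out lower numbers stand for less inhibition and higher numbers for more inhibition at the one dose given (going by the name of the read-out). Compound 1 `CC1=C(C(=O)Nc2ccc(Br)cc2)C(c2ccc(Cl)cc2Cl)N=C(SCc2ccccc2)N1` gives 1.5% in this assay. Compound 2 `CC1=C(C(=O)Nc2ccc(Br)cc2)C(c2ccc(Cl)cc2Cl)N=C(SCc2ccccc2Cl)N1`, which carries a chloro in place of hydrogen on an aromatic carbon, gives 3.1%; the step of a number 1.6 percentage points higher from compound 1 to compound 2 (within the scatter) lies within the scatter, so the two numbers cannot be told apart and compound 2 stands simply at the same low level as compound 1.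

Compound 3 `CC1=C(C(=O)Nc2ccc(Br)cc2)C(c2ccc(Cl)cc2Cl)N=C(SCc2cccc(Cl)c2)N1` differs from compound 2 by 3-chlorophenyl in place of 2-chlorophenyl on a saturated chain carbon bound to a sulfur. Going by the values given here, no measured step moves a chloro from one aromatic carbon to another; the only step known, a number 1.6 percentage points higher from compound 1 to compound 2 (within the scatter), adds one and stays within the scatter. On that ground the change is expected to bring no step beyond the scatter, and the expected step of a number 0.1 percentage points lower from compound 2 to compound 3 (within the scatter) is estimated to be small. Compound 3 is therefore expected to give 3%, with the estimate lying between -6% and 12%.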

Compound 3, a percentage reported as inhibition, in the whole organism at one dose (the size of the read-out at that dose, not a potency): 1.5%
Beside the measured number, compound 3's estimate is 1.5 percentage points above it; the measured number falls inside the stated range.
By their numbers in this assay, from the lowest: compounds 1, 3 and 2 (each within the scatter of the next).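

In this assay, 3-chlorophenyl in place of 2-chlorophenyl on a saturated chain carbon bound to a sulfur gives a number 1.6 percentage points lower from compound 2 to compound 3 (within the scatter), so this exchange of one chlorophenyl for the other cannot be told from no effect. Read against the compound without a chloro on that aromatic ring, the same addition gives no change at the digits printed from compound 1 to compound 3 (within the scatter), which shows that a second chlorophenyl at this place also stays at the low level of compound 1. Thus neither chlorophenyl tested here stands apart from the phenyl group of compound 1.

As far as these compounds go, whether 4-chlorophenyl, or an aminophenyl or carboxyphenyl group, at the same place would give a number beyond the scatter remains open. Nothing available here bears on why the three numbers stay together.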